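Furan-2-yl for cyclopentyl: from compound 3 to compound 4

A few compounds are considered here, and "the series" means these few. Any claim that something is new, unique, unknown or untested is made for them only; others in the source may bear on it.

Of the compounds shown here, three have been measured in a functional assay on the whole organism (plasma, strain Sprague-Dawley) with Rattus norvegicus as the target, with a stated time of 2 h, at a dose of 12.5 mg/kg by the oral route; on this read-out higher numbers stand for a stronger effect at the one dose given and lower numbers for a weaker effect. Compound 1 `c1ccc(C(/N=C2\CCCCCN2)C2CC2)cc1` gives 5%; compound 2 `c1ccc(C(/N=C2\CCCCCN2)C2CCC2)cc1` gives 14%; compound 3 `c1ccc(C(/N=C2\CCCCCN2)C2CCCC2)cc1` gives 12%. Compound 3 stands second highest of the three numbers, but its neighbours lie close: the step of a number 2 percentage points lower from compound 2 to compound 3 (within the scatter) and the step of a number 7 percentage points higher from compound 1 to compound 3 (within the scatter) are both within the scatter, as is a number 9 percentage points higher from compound 1 to compound 2 (within the scatter). Across these three, changing the saturated ring on the saturated chain carbon bound to an aromatic carbon and a double-bonded nitrogen has made no difference beyond the scatter.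

Compound 4 `c1ccc(C(/N=C2\CCCCCN2)c2ccco2)cc1` carries furan-2-yl in place of cyclopentyl on a saturated chain carbon bound to an aromatic carbon and a double-bonded nitrogen. Going by the values given here, none of the measured steps tests this exact change; all three exchanged one saturated carbon ring for another, and each stayed within the scatter. The furan-2-yl ring, with its one hetero atom and one hydrogen-bond acceptor, lies outside that set, so the measured steps offer only weak guidance. No step beyond the scatter is expected for no change at the digits printed from compound 3 to compound 4 (within the scatter), taking compound 3 at 12% as the nearest comparison. Compound 4 is therefore estimated at 12%, with a range from 0% to 30%, anchored on the low read-outs seen so far in the series.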

Compound 4, a percentage reported as inhibition, in the whole organism at one dose (the size of the read-out at that dose, not a potency): 5%
The estimate for compound 4 lay 7 percentage points above the measured number; measured number inside the range.
By their numbers in this assay, from the lowest: compounds 1, 4, 3 and 2 (each within the scatter of the next).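

In this assay, the position on a saturated chain carbon bound to an aromatic carbon and a double-bonded nitrogen now tolerates a five-membered aromatic ring with a hetero atom without leaving the scatter of any saturated carbon ring: a number 7 percentage points lower from compound 3 to compound 4 (within the scatter), a number 9 percentage points lower from compound 2 to compound 4 (within the scatter), and no change at the digits printed from compound 1 to compound 4 (within the scatter). The earlier steps shown here only exchanged one saturated carbon ring for another, whereas furan-2-yl also brings an oxygen and a hydrogen-bond acceptor, and even this exchange, at the same count of heavy atoms as cyclopentyl, separates no compound at the one dose given. Nothing available bears on why the read-out responds so little to this change.

As far as these compounds go, whether any group at this place can move the read-out beyond the scatter remains open, for instance an amine, a carboxylic acid, a pyridine ring or a longer chain such as n-butyl. The one-dose read-out also leaves open whether these four compounds would show a stronger or weaker effect than one another at any other dose, as the values describe only the size of the effect at that dose.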